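The source may report more compounds than this note shows. Statements on the series, on what has been measured and on what is new or still open speak of the compounds shown alone.

Measured in an in vitro ADME assay on microsomes from liver (Homo sapiens) for metabolic stability; on this read-out lower numbers stand for slow clearance and higher numbers for fast clearance:
- Compound 1 `Cc1nnc(C2CCN(c3ccccn3)CC2)n1-c1ccc(C#N)cc1`: < 8 mL.min-1.g-1 (a limit of the assay, not a number)
- Compound 2 `Cc1nnc(C2CCN(c3ccccn3)CC2)n1-c1ccc(Cl)cc1`: 23 mL.min-1.g-1
- Compound 3 `Cc1nnc(C2CCN(c3ccccn3)CC2)n1Cc1cccc(Cl)c1`: 29 mL.min-1.g-1

Compound 3 has a close neighbour in this small set. The measured swap of the group on the aromatic nitrogen, a 1.3-fold higher number from compound 2 to compound 3 (0.10 log units; within the scatter), stays within the scatter. The other two steps, an at least 2.8-fold higher number from compound 1 to compound 2 (0.45 log units; beyond the scatter) and an at least 3.6-fold higher number from compound 1 to compound 3 (0.55 log units; beyond the scatter), go beyond it.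

Compound 4 `Clc1cccc(Cn2c(Cn3nccn3)nnc2C2CCN(c3ccccn3)CC2)c1` keeps all of compound 3 except for one place: 2H-1,2,3-triazol-2-yl in place of hydrogen on a saturated chain carbon bound to an aromatic carbon. The methyl thus becomes (2H-1,2,3-triazol-2-yl)methyl.

Going by the values given here, none of the measured steps touches this place, as all of them concern the group on the aromatic nitrogen. They show only how far this assay has moved within the series, so they offer weak guidance here. Among the compounds with values here, with no direct precedent, the best starting point is compound 3 at 29 mL.min-1.g-1, and no step beyond the scatter is expected, though with wide uncertainty. The expected step is a 1.0-fold higher number from compound 3 to compound 4 (0.01 log units; within the scatter). For compound 4 the estimated value is 30 mL.min-1.g-1, with an expected range from 12 mL.min-1.g-1 to 75 mL.min-1.g-1.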

Compound 4, intrinsic clearance in microsomes: 104 mL.min-1.g-1
Beside the measured number, compound 4's estimate is 3.5-fold (0.54 log units) below it; the whole stated range lies below it.
By their numbers in this assay, from the lowest: compounds 2 and 3 (each within the scatter of the next); then compound 4. At a limit, below all of these: compound 1.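

Until now, every measured step concerned the group on the aromatic nitrogen, so the methyl had no test of its own. In this assay, placing 2H-1,2,3-triazol-2-yl on this saturated chain carbon bound to an aromatic carbon gives a 3.6-fold higher number from compound 3 to compound 4 (0.55 log units; beyond the scatter), which shows that a change at this place can move the read-out beyond the scatter, here towards faster clearance. Nothing measured here explains this rise.

With one group at this place, the compounds shown cannot tell whether the triazole ring itself matters or whether any larger group would do the same, such as an ethyl, a methoxymethyl or an aminomethyl. Also open, as far as these compounds go, is whether the same change raises the number when the group on the aromatic nitrogen is 4-cyanophenyl or 4-chlorophenyl, as in compound 1 and compound 2.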